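This account rests on a few compounds, and the source may have more. Where it says the series, first, only, none or still open, it means among the compounds named here.

Measured compounds:
- compound 1, `COc1cccc(OC2=C(Cl)C(=O)c3c(OC(C)=O)ccc(OC(C)=O)c3C2=O)c1`: 200 nM
- compound 2, `COc1cc(OC)cc(OC2=C(Cl)C(=O)c3c(OC)ccc(OC)c3C2=O)c1`: 120 nM

In a functional assay on HL-60 cells (Homo sapiens) for cytotoxicity (on this read-out lower numbers stand for stronger inhibition and higher numbers for weaker inhibition), compound 1 gives 200 nM, the higher of the two numbers recorded. Compound 2 gives 120 nM in this assay, and the gap between compound 2 and compound 1 lies within the scatter, so the two cannot be ordered. Within the data shown here, compounds 1 and 2 differ in more than one place, so no single step connects them.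

Compound 3, `COc1cc(OC)cc(OC2=C(Cl)C(=O)c3c(OC(C)=O)ccc(OC(C)=O)c3C2=O)c1`, is not yet measured. It differs from compound 1 by methoxy in place of hydrogen on an aromatic carbon, so that the 3-methoxyphenyl of compound 1 becomes the 3,5-dimethoxyphenyl seen in compound 2, while the core of compound 1 with its two acetoxy groups is kept.

Among the measured compounds shown here, no measured pair shows this change on its own. Compound 2 carries the same 3,5-dimethoxyphenyl on a different core and gives 120 nM, which does not separate from compound 1 beyond the scatter. The step from compound 1 to compound 3 in this assay is therefore expected to be small, a 1.3-fold lower number from compound 1 to compound 3 (0.10 log units; within the scatter), with no direction claimed beyond the scatter. Compound 3 is estimated at 160 nM, in the range 60 nM to 450 nM.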

Compound 3, half-maximal inhibitory concentration: 500 nM
Beside the measured number, compound 3's estimate is 3.1-fold (0.49 log units) below it, outside the stated range (above it).
By their numbers in this assay, from the lowest: compounds 2 and 1 (each within the scatter of the next); then compound 3.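

In this assay, among these compounds, going from 3-methoxyphenyl to 3,5-dimethoxyphenyl with the core of compound 1 kept gives a 2.5-fold higher number from compound 1 to compound 3 (0.40 log units; beyond the scatter) and is the first change that can be read on its own. The place on the aromatic ring that is meta to a large group and meta to a methoxy group is therefore not indifferent to an added methoxy on this core, with the higher number standing for weaker inhibition and the step modest in size. Nothing on hand bears on the reason for this step.

As far as these compounds go, whether the same step holds on the core of compound 2, which carries the 3,5-dimethoxyphenyl and gives 120 nM in this assay, stays open until a 3-methoxyphenyl partner on that core can be set against it. Also open, from the compounds shown here alone, is whether the step belongs to methoxy itself or would recur with another group at this place, such as hydroxyl, fluorine or a dimethylamino group.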